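This account rests on a few compounds, and the source may have more. Where it says the series, first, only, none or still open, it means among the compounds named here.

Compound 1 `CCCn1c(=O)[nH]c2nc(-c3ccc(S(=O)(=O)N4CCN(C(C)c5ccccc5)CC4)cc3)[nH]c2c1=O` gives 0%. Compound 2 `CCCn1c(=O)[nH]c2nc(-c3ccc(S(=O)(=O)N4CCN(c5ccc(I)cc5)CC4)cc3)[nH]c2c1=O` gives 36%.

In an assay on CHO cells for displacement of a labelled ligand from adenosine receptor A3 (Homo sapiens), read by scintillation counting, with a stated time of 45 min, tested at 1 uM, in the presence of a further agent that is not named here (a higher number here means more inhibition at the concentration tested (going by the name of the read-out), a lower number less inhibition), compound 2 stands highest of the two numbers. Among the compounds with values here, the only measured step at the same position is a number 36 percentage points higher from compound 1 to compound 2 (beyond the scatter). Compound 3 `CCCn1c(=O)[nH]c2nc(-c3ccc(S(=O)(=O)N4CCN(c5ccccc5Cl)CC4)cc3)[nH]c2c1=O` carries 2-chlorophenyl in place of 4-iodophenyl on an amine nitrogen in a ring. That earlier step bears on it only loosely: it shows that changing the group on the ring nitrogen can move the read-out well beyond the scatter, but an exchange of one aryl group for another has not been measured. Compound 3 is therefore expected to fall moderately, by a number 16 percentage points lower from compound 2 to compound 3 (beyond the scatter), with wide uncertainty. The estimate for compound 3 is 20%, between 0% and 45%.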

Compound 3, a percentage reported as inhibition, at one concentration (the size of the read-out at that concentration, not a potency): 32%
Compound 3: middle estimate off by 12 percentage points, on the low side; low and high end bracket the measured number.
By their numbers in this assay, from the lowest: compound 1; then compounds 3 and 2 (each within the scatter of the next).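

In this assay, replacing one halogen-bearing phenyl group with another on the ring nitrogen changes little (a number 4 percentage points lower from compound 2 to compound 3 (within the scatter)), so 2-chlorophenyl and 4-iodophenyl cannot be told apart here. The large rise over 1-phenylethyl also holds for 2-chlorophenyl (a number 32 percentage points higher from compound 1 to compound 3 (beyond the scatter)), so it is not confined to the 4-iodophenyl group. Nothing given here explains either step.

Still open, on these data alone, is how an unsubstituted phenyl group would read at this position, and whether 4-chlorophenyl or 2-iodophenyl would match these two. A benzyl group or a pyridine ring on this nitrogen also remains to be placed.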